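The source may hold more compounds than are shown below. What is called first, only, known or untested is meant among the compounds shown, and "the series" means these compounds.

Measured compounds:
Compound 1 `Cc1cc(Nc2cc(-c3ccccc3)[nH]n2)n2nc(SCc3ccc([N+](=O)[O-])cc3)nc2n1` — 4250 nM
Compound 2 `Cc1cc(Nc2cc(-c3ccccc3)[nH]n2)n2nc(SCc3c(Cl)cccc3Cl)nc2n1` — 5280 nM
Compound 3 `Cc1cc(Nc2cc(-c3ccccc3)[nH]n2)n2nc(SCC3CC3)nc2n1` — 16100 nM

All three were tested in a functional assay on MGC-803 cells (Homo sapiens) for inhibition, read by MTT assay, with a stated time of 72 h; a higher number here means a weaker inhibitor, a lower number a stronger inhibitor. Compound 3 gives the highest number of the three in this assay; its nearest neighbour is compound 2, and the step of a 3.0-fold higher number from compound 2 to compound 3 (0.48 log units; beyond the scatter) lies beyond the scatter, as does the larger step of a 3.8-fold higher number from compound 1 to compound 3 (0.58 log units; beyond the scatter). The two aryl-bearing compounds sit close together, the step of a 1.2-fold higher number from compound 1 to compound 2 (0.09 log units; within the scatter) being within the scatter.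

The step now considered leads from compound 3 to compound 4 `C#CCSc1nc2nc(C)cc(Nc3cc(-c4ccccc4)[nH]n3)n2n1`, which has not been measured in this assay. The structural change is ethynyl in place of cyclopropyl on a saturated chain carbon bound to a sulfur. Among the measured compounds shown here, no measured pair shows the exchange of cyclopropyl for ethynyl, so the expectation can rest only on the two steps that replaced a substituted phenyl by cyclopropyl on the same carbon: both raised the number by a modest amount. Compound 4 carries a group that, like cyclopropyl, has no ring aromaticity and is of similar size, so no step beyond the scatter is expected in this assay, with the number leaning if anything slightly upward.

For compound 4 the estimate is 18000 nM, between 8000 nM and 45000 nM, so that the expected step is a 1.1-fold higher number from compound 3 to compound 4 (0.05 log units; within the scatter).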

Compound 4, half-maximal inhibitory concentration: 13400 nM
The estimate for compound 4 lay 1.3-fold (0.13 log units) above the measured number; the measured number falls inside the stated range.
By their numbers in this assay, from the lowest: compounds 1 and 2 (each within the scatter of the next); then compounds 4 and 3 (each within the scatter of the next).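

In this assay, the exchange on a saturated chain carbon bound to a sulfur gives a 1.2-fold lower number from compound 3 to compound 4 (0.08 log units; within the scatter), so this assay does not separate cyclopropyl, with its three-membered ring, from ethynyl, with its triple bond and no ring. Among the compounds shown here, the gap to the aryl-bearing compounds, earlier seen only with cyclopropyl, now appears with a second non-aromatic group, as a 2.5-fold higher number from compound 2 to compound 4 (0.40 log units; beyond the scatter) and a 3.2-fold higher number from compound 1 to compound 4 (0.50 log units; beyond the scatter) show, although both of these steps are modest. No measurement bears on what lies behind this gap.

The compounds shown leave open whether an unsubstituted phenyl on this carbon would fall with compounds 1 and 2 or with compounds 3 and 4, and whether a longer chain, an amine or a carboxylic acid in the same place would change the number at all. They also leave open whether the split between the two pairs of compounds would persist on other cell lines or with a different shared core.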